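This account rests on a few compounds, and the source may have more. Where it says the series, first, only, none or still open, it means among the compounds named here.

Of the compounds shown here, three built on one shared core have been measured. Compound 1 `COc1cccc(/C=C2\CCC/C(=C\c3ccc(Cl)cc3)C2=O)c1OC` gives 10300 nM in a functional assay on MCF7 cells (Homo sapiens) for cytotoxicity, read by MTT assay, with a stated time of 72 h; on this read-out lower numbers stand for stronger inhibition and higher numbers for weaker inhibition. Compound 2 `COc1cccc(/C=C2\CCC/C(=C\c3ccccc3Br)C2=O)c1OC` gives 9700 nM, and compound 3 `COc1cccc(/C=C2\CCC/C(=C\c3ccc(Br)cc3)C2=O)c1OC` gives 13800 nM. Among these three numbers the one for compound 2 is the smallest, but the steps around it are small: a 1.1-fold lower number from compound 1 to compound 2 (0.03 log units; within the scatter) and a 1.4-fold higher number from compound 2 to compound 3 (0.15 log units; within the scatter). Both lie within the scatter, and so does the step of a 1.3-fold higher number from compound 1 to compound 3 (0.13 log units; within the scatter), so the three compounds cannot be told apart on this read-out.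

Compound 4 `COc1ccccc1/C=C1\CCC/C(=C\c2cccc(OC)c2OC)C1=O` differs from compound 2 in one place: methoxy in place of bromo on an aromatic carbon. Within the data shown here, none of the measured steps swaps a halogen for a methoxy group; they only trade one halogen for another or move a halogen around the ring, and every one of them stayed within the scatter. There is therefore no measured evidence that a change on this ring shifts the number much in either direction. The expectation for compound 4 is accordingly a step of a 1.0-fold higher number from compound 2 to compound 4 (0.01 log units; within the scatter), within the scatter. Compound 4 is estimated at 10000 nM in this assay, with a range from 4000 nM to 25000 nM.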

Compound 4, half-maximal inhibitory concentration: 12000 nM
Estimate against measurement, compound 4: 1.2-fold (0.08 log units) below; the measured number falls inside the stated range.
By their numbers in this assay, from the lowest: compounds 2, 1, 4 and 3 (each within the scatter of the next).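

Among these compounds, compound 4 is the first compound here to carry something other than a halogen on this aromatic carbon, ortho to a large group: methoxy has two heavy atoms where bromo has one and adds one hydrogen-bond acceptor, yet in this assay the swap gives a 1.2-fold higher number from compound 2 to compound 4 (0.09 log units; within the scatter). The other two steps are also small, a 1.2-fold lower number from compound 3 to compound 4 (0.06 log units; within the scatter) and a 1.2-fold higher number from compound 1 to compound 4 (0.07 log units; within the scatter), so all four compounds now cannot be told apart on this read-out, and the tolerance seen among halogens extends, in this one case, to a group containing oxygen. No supporting measurement is available to explain why the number stays within the scatter after this swap.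

Still open, as far as these compounds go, is whether a group of a different kind at this spot, such as an amine, a carboxylic acid or a longer chain like butoxy, would produce a step beyond the scatter. Also open, from the compounds shown here alone, is how the number responds to changes on the other side of the shared core, which stays the same in all four compounds.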